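Changing the Aryl Group on the Ring Nitrogen

A few compounds are considered here, and "the series" means these few. Any claim that something is new, unique, unknown or untested is made for them only; others in the source may bear on it.

Among the measured compounds shown here, compound 2 `N#CC1=C(N)Oc2c(N)cc3nc4ccccc4nc3c2C12C(=O)N(Cc1cnnn1-c1cccc(C(F)(F)F)c1)c1ccccc12` gives 5400 nM in a functional assay on A549 cells (Homo sapiens) for antiproliferative activity, read by MTT assay, with a stated time of 48 h (a lower number here means a stronger inhibitor, a higher number a weaker inhibitor), and stands as the lower of the two numbers measured so far, while compound 1 `CCc1ccccc1-n1nncc1CN1C(=O)C2(C(C#N)=C(N)Oc3c(N)cc4nc5ccccc5nc4c32)c2ccccc21` gives 24600 nM. For the measured compounds named here, the one measured step, a 4.6-fold lower number from compound 1 to compound 2 (0.66 log units; beyond the scatter), bears directly on the next change, as it also exchanged the group on the same aromatic nitrogen. Compound 3 `Cc1ccc(-n2nncc2CN2C(=O)C3(C(C#N)=C(N)Oc4c(N)cc5nc6ccccc6nc5c43)c3ccccc32)cc1C` carries 3,4-dimethylphenyl in place of 3-(trifluoromethyl)phenyl on an aromatic nitrogen. For compound 3 a modest move back toward a higher number is expected, a 2.2-fold higher number from compound 2 to compound 3 (0.35 log units; beyond the scatter). Compound 3 is estimated at 12000 nM, within 5000 nM to 30000 nM.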

Compound 3, half-maximal inhibitory concentration: > 50000 nM
Compound 3: a limit, no number (the forecaster's own chance of this, stated with the estimate: 5%); at least 4.1-fold (0.61 log units) between middle value and limit.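

At this aromatic nitrogen, 3,4-dimethylphenyl in place of 3-(trifluoromethyl)phenyl gives an at least 9.2-fold higher number from compound 2 to compound 3 (0.96 log units; beyond the scatter), although both groups keep one six-membered aromatic ring, so the groups on that ring alone can move the result strongly. Against 2-ethylphenyl, the same group gives an at least 2.0-fold higher number from compound 1 to compound 3 (0.30 log units; that floor lies within the scatter), so no order between those two can be claimed. Compound 3 reads only as a limit of the assay, not a number: the limit of > 50000 nM in this assay, at which 1 of the 3 values shown sits.

Still open, as far as these compounds go, is how a plain phenyl, or a phenyl carrying a single methyl or an amine, would read at this nitrogen.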